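Ring amine substitution and maximal response in the sulfone series

The compounds below may be only part of what the source reports. "The series", "measured", "known", "first", "only" and "open" are said of these compounds alone.

Compound 2 `CCN1CCCC(n2cc(S(=O)(=O)c3cccc(F)c3)c3cccnc32)C1` stands lowest of the two measured numbers in a functional assay on HeLa cells for agonist activity at 5-hydroxytryptamine receptor 6 (Homo sapiens), read by cAMP accumulation and immunoassay; a higher number here means a larger maximal response, a lower number a smaller maximal response. Among the compounds with values here, compound 1 `O=S(=O)(c1cccc(F)c1)c1cn(C2CCCNC2)c2ncccc12` gives 84% in this assay, and compound 2 gives 63%; the one step between them, a number 21 percentage points lower from compound 1 to compound 2 (beyond the scatter), came from an ethyl in place of hydrogen on the amine nitrogen in the ring. Compound 3 `CC(C)N1CCCC(n2cc(S(=O)(=O)c3cccc(F)c3)c3cccnc32)C1` carries the change (methyl in place of hydrogen on a saturated chain carbon bound to an amine nitrogen in a ring and a saturated chain carbon). Within the data shown here, no measured step shares this exact change; the only step that bears on it is the growth of the same ring amine substituent from compound 1 to compound 2, which lowered the maximal response by a modest amount. A further addition at the same position is therefore expected to lower the maximal response again in this assay, modestly or not beyond the scatter, giving an expected step of a number 9 percentage points lower from compound 2 to compound 3 (within the scatter). For compound 3 the estimate in this assay is 54%, expected within 38% to 70%.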

Compound 3, largest response reached (Emax), in percent of the reference or control that the assay uses: 67%
The estimate for compound 3 lay 13 percentage points below the measured number; the range from low to high includes it.
By their numbers in this assay, from the lowest: compounds 2 and 3 (each within the scatter of the next); then compound 1.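

In this assay, ethyl to isopropyl on the ring amine gives a number 4 percentage points higher from compound 2 to compound 3 (within the scatter) and so does not extend the earlier fall: the added methyl on the saturated chain carbon bound to an amine nitrogen in a ring leaves the two substituted amines unresolved. Against the free amine, the isopropyl still gives a number 17 percentage points lower from compound 1 to compound 3 (beyond the scatter) and so stands with the ethyl step, a number 21 percentage points lower from compound 1 to compound 2 (beyond the scatter) in this series; across these three compounds, the separation lies between hydrogen and either alkyl group, not between the two alkyl groups. No measurement at hand accounts for this pattern.

Going by these compounds, whether a methyl, a cyclopropyl or a benzyl on the same amine nitrogen would sit with compound 2 and compound 3 or with compound 1 stays open. On these data alone, the core is shared by all three compounds, so whether the step from hydrogen to isopropyl holds on another core also stays open.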